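Boc removal on the aniline nitrogen: compound 2 to compound 3

The source may hold more compounds than are shown below. What is called first, only, known or untested is meant among the compounds shown, and "the series" means these compounds.

Compound 1 `O=C(Nc1cccc(C(=O)O/N=C2\CCCc3onc(-c4ccccc4F)c32)c1)c1cccc(F)c1` and compound 2 `CC(C)(C)OC(=O)Nc1cccc(C(=O)Nc2cccc(C(=O)O/N=C3\CCCc4onc(-c5ccc(F)cc5)c43)c2)c1` share one core. In a functional assay on HCC1954 cells (Homo sapiens) for antiproliferative activity, read by MTT assay, with a stated time of 72 h (on this read-out lower numbers stand for stronger inhibition and higher numbers for weaker inhibition), compound 1 reaches only the assay limit of > 25000 nM, a limit and not a number. Compound 2 likewise gives only the limit of > 25000 nM in this assay. Both shown values sit at this same limit (the limit of > 25000 nM in this assay, at which 2 of the 2 values shown sit), so compound 2 stands level with the only other compound measured. Compound 3 `Nc1cccc(C(=O)Nc2cccc(C(=O)O/N=C3\CCCc4onc(-c5ccc(F)cc5)c43)c2)c1` differs by hydrogen in place of tert-butoxycarbonyl on a nitrogen on an aromatic ring. Among the measured compounds shown here, no measured step covers this change; a limit again, or a weak number near it, is expected. For compound 3 the expected value in this assay is 20000 nM (from 4000 nM to 60000 nM). The expected step is an at least 1.2-fold lower number from compound 2 to compound 3 (0.09 log units; that floor lies within the scatter).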

Compound 3, half-maximal inhibitory concentration: > 25000 nM
Compound 3 ended at the assay's limit; the forecaster's own chance of this, stated with the estimate: 60%; middle value at least 1.2-fold (0.09 log units) away from the limit.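

Compound 2 and compound 3 both sit at a limit, not a number, so no step can be read for the loss of tert-butoxycarbonyl: the limit of > 25000 nM in this assay, at which 3 of the 3 values shown sit. The compounds shown leave open which structural change, if any, gives a readable antiproliferative value.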